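The compounds below may be only part of what the source reports. "The series", "measured", "known", "first", "only" and "open" are said of these compounds alone.

Measured so far:
- compound 1, `CCc1nc(-c2ccc(C(C)(C)C)cc2)c(C(=O)N2CCN(c3cccc(OC)c3)CC2)o1`: "not active" (no number reported)
- compound 2, `Cc1nc(-c2ccccc2)c(C(=O)N2CCN(c3cccc(C)c3C)CC2)o1`: 35 nM
- compound 3, `Cc1nc(-c2ccc(F)cc2)c(C(=O)N2CCN(c3ccc(Cl)cc3)CC2)o1`: "not active" (no number reported)

Within the data shown here, compound 2 is the only member of the series with a number in a functional assay on HL-60 cells (Homo sapiens) for inhibition, read by MTT assay, with a stated time of 72 h; a lower number here means a stronger inhibitor, a higher number a weaker inhibitor; in this assay compound 2 gives 35 nM. Compound 1 is reported in this assay as "not active" (no number reported) without a number, and compound 3 likewise as "not active" (no number reported). Neither compound 1 nor compound 3 differs from compound 2 in one place only, so no single step can be read between them; their two entries show only that two other substitution patterns on the shared core gave no measurable inhibition.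

Compound 4, `COc1cccc(N2CCN(C(=O)c3oc(C)nc3-c3ccccc3)CC2)c1`, is unmeasured and differs from compound 2 in one place: 3-methoxyphenyl in place of 2,3-dimethylphenyl on an amine nitrogen in a ring. Among the measured compounds shown here, no step between measured compounds is available to calibrate this change. Compound 1 carries the same 3-methoxyphenyl group and is without a number, but it also differs elsewhere, so that entry cannot be assigned to the phenyl exchange alone. A modest loss is expected, of a size near the edge of the scatter: the step from compound 2 to compound 4 is estimated at a 3.4-fold higher number from compound 2 to compound 4 (0.54 log units; beyond the scatter). Compound 4 is therefore expected at 120 nM, within 30 nM to 600 nM.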

Compound 4, half-maximal inhibitory concentration: 34.8 nM
For compound 4 the middle estimate is 3.4-fold (0.54 log units) above the measured one; low and high end bracket the measured number.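

In this assay, the exchange of 2,3-dimethylphenyl for 3-methoxyphenyl on the amine nitrogen in a ring gives a 1.0-fold lower number from compound 2 to compound 4 (0.00 log units; within the scatter), so this pair shows no separation at this position. On this core, the two methyl groups of 2,3-dimethylphenyl are therefore not required for a nanomolar number, and 3-methoxyphenyl, with its one hydrogen-bond acceptor, serves equally well in this assay. No measurement shown offers an explanation for this equivalence.

The entries for compound 1 and compound 3 differ from the other compounds in more than one place, so no step can be read from them. Open, from the compounds shown here alone, is whether a phenyl ring bearing an amine or a carboxylic acid, or a benzyl group, on the same nitrogen would stand level with compound 2 and compound 4.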